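Replacing an ortho-substituted phenyl on the triazole ring

The source may report more compounds than this note shows. Statements on the series, on what has been measured and on what is new or still open speak of the compounds shown alone.

Measured compounds in a functional assay on DU-145 cells (Homo sapiens) for antiproliferative activity, read by MTT assay, with a stated time of 48 h; on this read-out higher numbers stand for weaker inhibition and lower numbers for stronger inhibition:
- compound 1, `C/C(=C\CC/C(C)=C/CC[C@@H]1[C@@]2(C)CCC(=O)C(C)(C)[C@H]2CC[C@@]1(C)O)CC/C=C(\C)C(=O)OCc1cn(-c2cccc(O)c2)nn1`, gives 28400 nM
- compound 2, `C/C(=C\CC/C(C)=C/CC[C@@H]1[C@@]2(C)CCC(=O)C(C)(C)[C@H]2CC[C@@]1(C)O)CC/C=C(\C)C(=O)OCc1cn(-c2ccccc2C)nn1`, gives only a limit of the assay, > 150000 nM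
- compound 3, `C/C(=C\CC/C(C)=C/CC[C@@H]1[C@@]2(C)CCC(=O)C(C)(C)[C@H]2CC[C@@]1(C)O)CC/C=C(\C)C(=O)OCc1cn(-c2ccccc2C(F)(F)F)nn1`, gives only a limit of the assay, > 150000 nM

All three share one core and differ only in the aryl group on the aromatic nitrogen of the triazole ring. Compound 3 stands at the weak end of what has been measured: its result is a limit, not a number, and (the limit of > 150000 nM in this assay, at which 2 of the 3 values shown sit). The step of an at least 5.2-fold higher number from compound 1 to compound 3 (0.72 log units; beyond the scatter) shows that moving from 3-hydroxyphenyl to 2-(trifluoromethyl)phenyl weakened inhibition. The step that the two limits leave unreadable from compound 2 to compound 3 cannot be sized, since both compounds sit at the limit.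

Compound 4, `C/C(=C\CC/C(C)=C/CC[C@@H]1[C@@]2(C)CCC(=O)C(C)(C)[C@H]2CC[C@@]1(C)O)CC/C=C(\C)C(=O)OCc1cn(-c2ccc(F)c(Cl)c2)nn1`, is not yet measured. Its change from compound 3 is 3-chloro-4-fluorophenyl in place of 2-(trifluoromethyl)phenyl on an aromatic nitrogen. For the measured compounds named here, no measured step shows a 3-chloro-4-fluorophenyl group, so the expectation rests on the weakness of compound 3 and on compound 1 being the only compound with a readable number. Compound 4 is expected to give 100000 nM, within 30000 nM to 200000 nM, which means an estimated step of an at least 1.5-fold lower number from compound 3 to compound 4 (0.17 log units; that floor lies within the scatter), with a real chance that the assay again reports only a limit.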

Compound 4, half-maximal inhibitory concentration: > 150000 nM
Compound 4 ended at the assay's limit; the forecaster's own chance of this, stated with the estimate: 45%; middle value at least 1.5-fold (0.17 log units) from the limit.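

In this assay, the two earlier compounds at the limit both carried a 2-substituted phenyl, 2-methylphenyl in compound 2 and 2-(trifluoromethyl)phenyl in compound 3, so the loss could have been tied to that kind of substitution. The 3-chloro-4-fluorophenyl group of compound 4 has no 2-substituent, yet the result is still weaker than that of compound 1, with an at least 5.2-fold higher number from compound 1 to compound 4 (0.72 log units; beyond the scatter), so a 2-substituent is not required for this loss, and only the 3-hydroxyphenyl of compound 1 gives a readable number among the aryl groups shown: the limit of > 150000 nM in this assay, at which 3 of the 4 values shown sit.

The steps among compounds 2, 3 and 4 cannot be read, since each of those results is a limit, so these three aryl groups cannot be ranked against one another.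

The compounds shown leave open whether the hydroxyl group itself accounts for the readable number of compound 1, or whether an unsubstituted phenyl would do as well. A plain phenyl, a 3-methoxyphenyl or a 3-aminophenyl on the same triazole nitrogen would each differ from compound 1 in one place and could help separate these possibilities.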